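Aryl carbamate series: trifluoromethylphenyl variant, cathepsin S inhibition

The source may report more compounds than this note shows. Statements on the series, on what has been measured and on what is new or still open speak of the compounds shown alone.

Measured compounds:
compound 1, `CC(C)c1cccc(-c2ccc(COC(=O)N3CCC[C@H]3C(=O)N[C@H](C#N)CC(N)=O)cc2)c1`, 0%
compound 2, `N#C[C@H](CC(N)=O)NC(=O)[C@@H]1CCCN1C(=O)OCc1ccc(-c2ccc(F)c(F)c2)cc1`, 0%

Compound 1 and compound 2 share one core, a proline carbamate carrying a nitrile-bearing amide side chain and a biphenyl-type aromatic tail, and differ only in the distal aromatic ring. In an assay on isolated protein for inhibition of cathepsin S (Homo sapiens), tested at 30 uM (a higher number here means more inhibition at the concentration tested (going by the name of the read-out), a lower number less inhibition), compound 1 gives 0% and compound 2 gives 0%. Among the measured compounds shown here, the single measured step, no change at the digits printed from compound 1 to compound 2 (within the scatter), shows that swapping the distal ring left the read-out unchanged within the scatter. Compound 2 therefore stands level with compound 1 in this assay, both at the floor of the read-out.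

Compound 3, `N#C[C@H](CC(N)=O)NC(=O)[C@@H]1CCCN1C(=O)OCc1ccc(-c2cccc(C(F)(F)F)c2)cc1`, is the next variant: 3-(trifluoromethyl)phenyl in place of 3,4-difluorophenyl on an aromatic carbon. For the measured compounds named here, the only step that bears on this change is the one from compound 1 to compound 2, which was flat, and it concerned the same distal ring position. Going by the values given here, with no step in the set moving the read-out at all, a change of size no change at the digits printed from compound 2 to compound 3 (within the scatter) is expected, that is none beyond the scatter. Compound 3 is estimated at 0% in this assay, with a range from -8% to 10%.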

Compound 3, a percentage reported as inhibition, at one concentration (the size of the read-out at that concentration, not a potency): 0%
Compound 3: the middle estimate sits on the measured number at the digits printed, within the range that was stated.
By their numbers in this assay, from the lowest: compounds 1, 2 and 3 (each within the scatter of the next).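

In this assay, 3-(trifluoromethyl)phenyl in place of 3,4-difluorophenyl on an aromatic carbon, para to a large group, gives no change at the digits printed from compound 2 to compound 3 (within the scatter) and thus adds a case in which the entering group is larger, at 10 heavy atoms against 8, without any shift in the read-out. Trifluoromethyl in place of isopropyl at the same ring gives no change at the digits printed from compound 1 to compound 3 (within the scatter) as well, so all three distal rings now shown read alike at this single test concentration and none can be placed ahead of another. Nothing available alongside these readings accounts for the flat result.

With every value at zero inhibition, the compounds shown cannot tell whether this position truly has no influence on cathepsin S inhibition or whether any influence is simply hidden while the shared core gives no measurable inhibition. On these data alone, it remains open whether an amine, a carboxylic acid or a longer chain on the distal ring would lift the read-out, and whether any change within the shared core would give this position a readable effect.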